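The compounds below may be only part of what the source reports. "The series", "measured", "known", "first", "only" and "open" are said of these compounds alone.

Compound 1, `O=C(c1ccc(NCc2cncn2Cc2ccc(-c3ccccc3)cc2)cc1-c1ccccc1)N1CCCCC1`, was examined in a toxicity assay on NIH3T3 cells (Mus musculus) for cytotoxicity, read by resazurin assay; a higher number here means that more compound is needed for the effect, a lower number that less compound is needed. For compound 1 the result is only a limit of the measurement, > 1000 nM, not a single number. Of the three results in hand, one sits at that limit, as shown by the limit of > 1000 nM in this assay, at which 1 of the 3 values shown sits. Compound 2, `COC(=O)c1ccc(NCc2cncn2Cc2ccccc2-c2ccccc2)cc1-c1ccccc1`, has "not determined" (no result reported) in this assay. Compound 3, `O=[N+]([O-])c1ccc(Cn2cncc2CNc2cccc(-c3ccccc3)c2)cc1`, gives 10000 nM in this assay. Going by the values given here, compound 1 thus stands on a limit alone, with one further entry that carries no number, and no two measured compounds differ from each other in a single place, so no measured step exists to lean on.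

Compound 4, `c1ccc(-c2ccc(Cn3cncc3CNc3ccc(-c4nc5ccccc5o4)c(-c4ccccc4)c3)cc2)cc1`, is the untested partner of compound 1. The change between the two is 1,3-benzoxazol-2-yl in place of (piperidin-1-yl)carbonyl on an aromatic carbon. Among the compounds with values here, with no measured step available, the expectation rests on the structural change alone, and the step is expected to be a step that the limit leaves unreadable from compound 1 to compound 4, which means nothing beyond the usual scatter, with the measured value likely still at or near the limit seen for its parent. Compound 4 is estimated at 3000 nM in this assay, with a plausible range from 1000 nM to 20000 nM.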

Compound 4, half-maximal effective concentration: > 10000 nM
Compound 4: only a limit was reported; the forecaster's own chance of this, stated with the estimate: 45%; middle value at least 3.3-fold (0.52 log units) away from the limit.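

Going by these compounds alone, compound 1 and compound 4 each carry only a limit of the measurement in this assay, not a single number, so no step between them can be read. The compounds shown leave open how much of either compound is needed for the effect, and whether 1,3-benzoxazol-2-yl in place of (piperidin-1-yl)carbonyl changes that amount at all.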